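Swapping thiophen-3-yl for thiophen-2-yl in compound 3

The source may report more compounds than this note shows. Statements on the series, on what has been measured and on what is new or still open speak of the compounds shown alone.

Compound 1 `CCc1ccc(Nc2nccc(-c3ccncc3)n2)cc1` gives 7700 nM
Compound 2 `COc1ccc(Nc2nccc(-c3ccsc3)n2)cc1` gives 15600 nM
Compound 3 `CN(C)c1ccc(Nc2nccc(-c3ccsc3)n2)cc1` gives 2100 nM

In a functional assay for inhibition, with Homo sapiens as the target (on this read-out lower numbers stand for stronger inhibition and higher numbers for weaker inhibition), compound 3 holds the lowest number of the three, at 2100 nM, and the gaps up to the other two lie beyond the scatter. The next compound, compound 4 `CN(C)c1ccc(Nc2nccc(-c3cccs3)n2)cc1`, has not yet been measured. It has thiophen-2-yl in place of thiophen-3-yl on an aromatic carbon, so the two share the same atoms, joined differently.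

Within the data shown here, no measured pair tests this swap directly. Among the measured compounds shown here, the only measured single-place step, a 7.4-fold lower number from compound 2 to compound 3 (0.87 log units; beyond the scatter), is modest and comes from dimethylamino in place of methoxy, a change that leaves thiophen-3-yl untouched. For the measured compounds named here, it therefore says little about the size of the new step, and compound 1 enters no such step at all. With no evidence for a direction, the expected result is a 1.1-fold higher number from compound 3 to compound 4 (0.06 log units; within the scatter), which means no expected shift beyond the scatter. The estimated value for compound 4 is 2400 nM (expected range 800 nM to 7000 nM).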

Compound 4, half-maximal inhibitory concentration: 900 nM
Compound 4: the middle estimate sits 2.7-fold (0.43 log units) above what was measured, within the range that was stated.
By their numbers in this assay, from the lowest: compound 4; then compound 3; then compound 1; then compound 2.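

In this assay, the swap gives a 2.3-fold lower number from compound 3 to compound 4 (0.37 log units; beyond the scatter) with no change in the atoms present, so how the ring is joined at this position matters, and not only which ring sits there. Thiophen-3-yl and thiophen-2-yl match in every count given for them, yet the two compounds stand apart by more than the scatter, something the earlier step of a 7.4-fold lower number from compound 2 to compound 3 (0.87 log units; beyond the scatter) could not show, as it left thiophen-3-yl untouched. Nothing measured here explains the difference between the two attachments.

On these data alone, it remains open whether thiophen-2-yl would give a similar step with methoxy in place of dimethylamino. As far as these compounds go, it is also open how other rings at this position, such as furan-2-yl or pyridin-2-yl, would compare with thiophen-2-yl.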